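From a hydroxyethyl amide to a morpholine amide

The source may report more compounds than this note shows. Statements on the series, on what has been measured and on what is new or still open speak of the compounds shown alone.

Of the compounds shown here, three have been tested in an assay on cells with Cystic fibrosis transmembrane conductance regulator variant F508del (Homo sapiens) as the target, read by fluorescence, with stated times of 24 h and 30 min; on this read-out lower numbers stand for an effect already at smaller amounts and higher numbers for an effect only at larger amounts of compound. Compound 1 `CN(C)CCN1CCN(c2nc(-c3ccccn3)nc3c2CN(S(=O)(=O)c2ccccc2)CC3)CC1` gives 100000 nM. Compound 2 `COc1ccc(NC(=O)n2nc(-c3sc(NC(=O)C(C)(C)C)nc3C)cc2Cc2cc(Cl)ccc2OC)cc1` gives 1000 nM. Compound 3 `COc1ccc(Cl)cc1Cc1cc(-c2sc(NC(=O)C(C)(C)C)nc2C)nn1C(=O)NCCO` gives 3020 nM, the second highest of the three numbers, closest to compound 2 and far from compound 1. Among the measured compounds shown here, the only measured change at the amide-type nitrogen is a 3.0-fold higher number from compound 2 to compound 3 (0.48 log units; beyond the scatter), a modest step. Compound 4 `COc1ccc(Cl)cc1Cc1cc(-c2sc(NC(=O)C(C)(C)C)nc2C)nn1C(=O)N1CCOCC1` differs from compound 3 by morpholin-4-yl in place of (2-hydroxyethyl)amino on a carbonyl carbon. For the measured compounds named here, no measured step covers this exact swap, so a change of about the size seen before, in either direction, is the most that can be expected. Compound 4 is therefore expected to give 2500 nM, within 800 nM to 8000 nM. This amounts to an expected step of a 1.2-fold lower number from compound 3 to compound 4 (0.08 log units; within the scatter).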

Compound 4, half-maximal effective concentration: 1000 nM
The estimate for compound 4 lay 2.5-fold (0.40 log units) above the measured number; the range from low to high includes it.
By their numbers in this assay, from the lowest: compounds 2 and 4 (each within the scatter of the next); then compound 3; then compound 1.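

Swapping to morpholin-4-yl on this carbonyl carbon gives a 3.0-fold lower number from compound 3 to compound 4 (0.48 log units; beyond the scatter) in this assay, so this position responds to the group's shape as well as to the aryl-for-hydroxyethyl change seen earlier. The other comparison shows no change at the digits printed from compound 2 to compound 4 (within the scatter), so the (4-methoxyphenyl)amino group and the morpholin-4-yl ring cannot be told apart here. A hydrogen on the attached nitrogen is therefore not needed to reach this level among these compounds.

Nothing available explains these differences. As far as these compounds go, whether piperidin-1-yl or a piperazine ring at this carbonyl carbon would shift the number remains open.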